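Trimming One Ester Arm: From Compound 3 to Compound 4

The compounds below may be only part of what the source reports. "The series", "measured", "known", "first", "only" and "open" are said of these compounds alone.

Measured so far in an assay on isolated protein (strain albino) for antagonist activity at Voltage-dependent L-type calcium channel subunit alpha-1C (Cavia porcellus); a higher number here means a weaker inhibitor, a lower number a stronger inhibitor:
compound 1 `CSc1ncc(C2C(C(=O)OCC(C)C)=C(C)NC(C)=C2C(=O)OCC(C)C)n1Nc1ccccc1` gives 6.71 nM
compound 2 `CSc1ncc(C2C(C(=O)OC3CCCC3)=C(C)NC(C)=C2C(=O)OC2CCCC2)n1Nc1ccccc1` gives 425 nM
compound 3 `CSc1ncc(C2C(C(=O)OCCCc3ccccc3)=C(C)NC(C)=C2C(=O)OCCCc2ccccc2)n1Nc1ccccc1` gives 3.15 nM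

Three compounds share one core and differ only in the two ester groups that flank it. Compound 3 has the lowest number of the three in this assay. Its nearest neighbour is compound 1, whose number is higher by a margin just beyond the usual scatter; compound 2 lies far above both.

Compound 4 `COC(=O)C1=C(C)NC(C)=C(C(=O)OCCCc2ccccc2)C1c1cnc(SC)n1Nc1ccccc1` keeps one ester of compound 3 unchanged and shortens the other: hydrogen in place of phenethyl on a saturated chain carbon bound to an oxygen next to a carbonyl group. In words, one 3-phenylpropyl ester becomes a methyl ester while the other is retained.

Within the data shown here, no measured pair shows this exact change, so the expectation rests on the spread of the three esters seen. Compound 4 is expected to sit close to compound 3, with a small step toward weaker inhibition that may not exceed the scatter, a 2.9-fold higher number from compound 3 to compound 4 (0.46 log units; beyond the scatter). The estimate for compound 4 is 9 nM, within a range from 2.5 nM to 35 nM.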

Compound 4, half-maximal inhibitory concentration: 3.05 nM
Compound 4: the middle estimate sits 3.0-fold (0.47 log units) above what was measured, and the stated range covers the measured number.
By their numbers in this assay, from the lowest: compounds 4 and 3 (each within the scatter of the next); then compound 1; then compound 2.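

In this assay, changing one 3-phenylpropyl ester to a methyl ester gives a 1.0-fold lower number from compound 3 to compound 4 (0.01 log units; within the scatter) and so leaves the number unchanged within the scatter. Compounds 1, 2 and 3 carry the same group on both ester arms, so they could not show one arm on its own; this step shows that, with the other 3-phenylpropyl ester retained, the phenethyl portion of this arm, with its aromatic ring, can give way to hydrogen without a measurable difference. Nothing available explains why the number holds.

On these data alone, whether the retained 3-phenylpropyl ester could also become a methyl ester remains open. So does the effect of placing a carboxylic acid or an amide on this arm instead of the methyl ester.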